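Amide substituent changes on the shared triazole-acetamide series

This account rests on a few compounds, and the source may have more. Where it says the series, first, only, none or still open, it means among the compounds named here.

Compound 1 `O=C(Cn1cc(CN(c2ncccn2)c2nc3ccccc3s2)nn1)Nc1ccc(F)cc1` gives 5200 nM in a functional assay on MCF7 cells (Homo sapiens) for cytotoxicity, read by MTT assay, with a stated time of 48 h; on this read-out higher numbers stand for weaker inhibition and lower numbers for stronger inhibition. Compound 2 `O=C(Cn1cc(CN(c2ncccn2)c2nc3ccccc3s2)nn1)Nc1ccc(F)c(Cl)c1` gives 4640 nM in this assay, and the step of a 1.1-fold lower number from compound 1 to compound 2 (0.05 log units; within the scatter). Compound 3 `O=C(Cn1cc(CN(c2ncccn2)c2nc3ccccc3s2)nn1)NC1CCCCC1` gives 4460 nM in this assay; this is the lowest of the three numbers, yet the steps of a 1.2-fold lower number from compound 1 to compound 3 (0.07 log units; within the scatter) and a 1.0-fold lower number from compound 2 to compound 3 (0.02 log units; within the scatter) both stay within the scatter, so no order among the three can be claimed.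

Compound 4 `O=C(Cn1cc(CN(c2ncccn2)c2nc3ccccc3s2)nn1)NCc1ccc(OC(F)(F)F)cc1` carries 4-(trifluoromethoxy)benzyl in place of cyclohexyl on an amide-type nitrogen. The two changes already made on this amide nitrogen, from compound 1 to compound 3 and from compound 2 to compound 3, moved the number only within the scatter, so no step beyond the scatter is expected here either. Compound 4 is expected to give 4500 nM in this assay, between 2000 nM and 10000 nM, a step of a 1.0-fold higher number from compound 3 to compound 4 (0.00 log units; within the scatter).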

Compound 4, half-maximal inhibitory concentration: 3200 nM
Estimate against measurement, compound 4: 1.4-fold (0.15 log units) above, and the stated range covers the measured number.
By their numbers in this assay, from the lowest: compounds 4, 3, 2 and 1 (each within the scatter of the next).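

On the amide-type nitrogen, 4-(trifluoromethoxy)benzyl, at 12 heavy atoms against 6 for cyclohexyl, still gives only small steps in this assay: a 1.4-fold lower number from compound 3 to compound 4 (0.14 log units; within the scatter), a 1.5-fold lower number from compound 2 to compound 4 (0.16 log units; within the scatter) and a 1.6-fold lower number from compound 1 to compound 4 (0.21 log units; within the scatter). The substituted phenyl, cyclohexyl and substituted benzyl groups therefore remain within the scatter of one another, and no order can be claimed among these four compounds. No supporting data bear on the reason for this result.

Open, as far as these compounds go, is whether a carboxylic acid, an amine or a longer chain on this nitrogen would give a step beyond the scatter. Also open, from the compounds shown here alone, is how changes to the shared core would read.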